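From hydroxymethyl to vinyl on a saturated ring carbon

The source may report more compounds than this note shows. Statements on the series, on what has been measured and on what is new or still open speak of the compounds shown alone.

Measured in a functional assay on A2780 cells (Homo sapiens) for antiproliferative activity, read by sulforhodamine B assay, with a stated time of 48 h; a lower number here means a stronger inhibitor of growth, a higher number a weaker inhibitor of growth:
- compound 1 `CC(C)(C)[Si](C)(C)OC[C@H]1OCCC[C@H]1O[Si](C)(C)C(C)(C)C`: > 100000 nM
- compound 2 `CC(C)(C)[Si](C)(C)O[C@@H]1CCCO[C@@H]1CO`: > 100000 nM

Compound 2 gives only a limit, > 100000 nM, and not a number. Compound 1 is also a limit, > 100000 nM. The series therefore stands at the limit of > 100000 nM in this assay, at which 2 of the 2 values shown sit, with no measured number to work from.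

Compound 3 `C=C[C@H]1OCCC[C@H]1O[Si](C)(C)C(C)(C)C` carries vinyl in place of hydroxymethyl on a saturated ring carbon. Among the compounds with values here, the only measured step nearby is a step that the two limits leave unreadable from compound 1 to compound 2. It concerns a different change and gives no size to carry over. Because of the limit of > 100000 nM in this assay, at which 2 of the 2 values shown sit, no gain in growth inhibition is expected, and a further limit is the likeliest report in this assay.

The expected outcome is a number no higher from compound 2 to compound 3 (the limit leaves the size open), with no shift beyond the scatter anticipated.

For compound 3 the estimated value is 100000 nM, with an expected range of 40000 nM to 200000 nM.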

Compound 3, concentration for 50% growth inhibition: 86000 nM
Beside the measured number, compound 3's estimate is 1.2-fold (0.07 log units) above it, and the stated range covers the measured number.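

In this assay, compound 3 gives the series its first true number, 86000 nM, so vinyl on this saturated ring carbon, next to the ring oxygen, is the first group shown to bring a reading inside the range of the assay. The change from hydroxymethyl to vinyl gives an at least 1.1-fold lower number from compound 2 to compound 3 (0.06 log units; that floor lies within the scatter), which means that this swap cannot yet be credited with any real gain in growth inhibition. Most of the series still rests at a limit, which leaves the true size of this change open: the limit of > 100000 nM in this assay, at which 2 of the 3 values shown sit.

The step from compound 1 to compound 2 cannot be read, and the compounds shown leave open whether another group on this ring carbon, such as an aminomethyl, a carboxylic acid or a longer alkyl chain, would move the number clearly beyond the scatter. Also open, on these data alone, is what the vinyl compound would give with a hydrogen atom in place of the group of 7 heavy atoms, on an oxygen on a saturated carbon.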